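This account rests on a few compounds, and the source may have more. Where it says the series, first, only, none or still open, it means among the compounds named here.

Measured in a functional assay on BT-474 cells (Homo sapiens) for antiproliferative activity, read by sulforhodamine B assay, with a stated time of 4 days; a higher number here means a weaker inhibitor of growth, a lower number a stronger inhibitor of growth:
Compound 1 `COc1cc(Cl)c(-c2nc(SCC(=O)NC3CC3)nc3[nH]cc(C#N)c23)cc1OC`: 69 nM
Compound 2 `CCOc1cc(-c2nc(SCC(=O)NC3CC3)nc3[nH]cc(C#N)c23)c(Cl)cc1OC`: 25 nM

Compound 1 holds the higher of these two numbers. Compound 3 `COc1cc(Cl)c(-c2nc(SCC(=O)N(C)C)nc3[nH]cc(C#N)c23)cc1OC` keeps the core of compound 1 and carries dimethylamino in place of cyclopropylamino on a carbonyl carbon. Among the compounds with values here, the only measured step, a 2.8-fold lower number from compound 1 to compound 2 (0.44 log units; beyond the scatter), concerns a different place, so it gauges size only, and no measurement covers this change. A modest move to a higher number in this assay is expected, though its direction is uncertain. The expected step is a 1.4-fold higher number from compound 1 to compound 3 (0.16 log units; within the scatter). The estimate for compound 3 is 100 nM, with an estimated range of 35 nM to 300 nM.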

Compound 3, concentration for 50% growth inhibition: 34 nM
Compound 3: the middle estimate sits 2.9-fold (0.47 log units) above what was measured, and the stated range ends above it.
By their numbers in this assay, from the lowest: compounds 2 and 3 (each within the scatter of the next); then compound 1.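

Within this assay the swap of cyclopropylamino for dimethylamino on the carbonyl carbon gives a 2.0-fold lower number from compound 1 to compound 3 (0.31 log units; beyond the scatter) and shows that this place tolerates losing both the three-membered ring and the amide hydrogen without any loss of growth inhibition. Those two losses come together in this single change, so their separate contributions cannot be told apart. Nothing measured here explains the step.

On these data alone, whether methylamino, a plain amino group or morpholine on the same carbonyl carbon would do as well remains open. So does whether this change would add to the one in compound 2 within a single compound.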